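A few compounds are considered here, and "the series" means these few. Any claim that something is new, unique, unknown or untested is made for them only; others in the source may bear on it.

Compound 1 `C/C(=C\c1cc(-c2ccc(C)cc2)cs1)C(N)=O`: > 50000 nM in a functional assay on HO8910 cells (Homo sapiens) for cytotoxicity, read by CCK-8 assay, with a stated time of 24 h; on this read-out lower numbers stand for stronger inhibition and higher numbers for weaker inhibition
Compound 2 `C/C(=C\c1cc(-c2ccc(F)cc2)cs1)C(N)=O`: > 50000 nM in this assay

Compound 2 stands at a limit of the assay rather than at a number, as one of the values at the limit of > 50000 nM in this assay, at which 2 of the 2 values shown sit. Compound 1 also stands at a limit, so the step that the two limits leave unreadable from compound 1 to compound 2 cannot be read. Compound 3 `C/C(=C\c1cc(-c2ccc(C#N)cc2)cs1)C(N)=O` differs from compound 2 by cyano in place of fluoro on an aromatic carbon. Among the compounds with values here, no measured step gives a readable size, so no direction beyond the scatter can be expected in this assay. Compound 3 is therefore expected to sit at a limit again, with an estimated 70000 nM, between 30000 nM and 200000 nM, the expected step being a step that the limit leaves unreadable from compound 2 to compound 3.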

Compound 3, half-maximal inhibitory concentration: 130 nM
Beside the measured number, compound 3's estimate is 540-fold (2.73 log units) above it; measured number below the stated range.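

In this assay, the group at this place on the six-membered aromatic ring turns out to matter a great deal: cyano in place of fluoro gives an at least 380-fold lower number from compound 2 to compound 3 (2.58 log units; beyond the scatter), and cyano in place of methyl gives an at least 380-fold lower number from compound 1 to compound 3 (2.58 log units; beyond the scatter). The step between compound 1 and compound 2 cannot be read, and neither compound gave a number, so only compound 3 shows that this position can respond at all: the limit of > 50000 nM in this assay, at which 2 of the 3 values shown sit.

The compounds shown leave open whether cyano stands alone here or whether another group, such as an amine or a carboxylic acid, would also lower the number.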